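Swapping Nitro for Chloro on an Aromatic Carbon

The source may report more compounds than this note shows. Statements on the series, on what has been measured and on what is new or still open speak of the compounds shown alone.

In a functional assay on NCI/ADR cells (Homo sapiens) for cytotoxicity, read by sulforhodamine B assay (a higher number here means a weaker inhibitor of growth, a lower number a stronger inhibitor of growth), compound 1 (`CC1=CC[C@@H]([C@@](C)(O)CCCC(C)(C)NC(=S)NN)CC1`) gives 760 nM. Compound 2 (`CC1=CC[C@@H]([C@@](C)(O)CCCC(C)(C)NC(=S)N/N=C\c2ccc(C)cc2)CC1`), which carries an added aromatic ring, gives 6510 nM. That move is an 8.6-fold higher number from compound 1 to compound 2 (0.93 log units; beyond the scatter). Compound 3 (`CC1=CC[C@@H]([C@@](C)(O)CCCC(C)(C)NC(=S)N/N=C\c2ccc([N+](=O)[O-])cc2)CC1`) gives 12800 nM, which matches compound 2 within the scatter and stands well clear of compound 1 beyond it.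

Compound 4 (`CC1=CC[C@@H]([C@@](C)(O)CCCC(C)(C)NC(=S)N/N=C\c2ccc(Cl)cc2)CC1`) has not yet been measured. It has chloro in place of nitro on an aromatic carbon, (chloro in place of nitro on an aromatic carbon); the same difference reads as 4-nitrophenyl to 4-chlorophenyl.

Among the measured compounds shown here, the most relevant evidence is the one measured change at this same aromatic carbon, nitro in place of methyl, which is a 2.0-fold higher number from compound 2 to compound 3 (0.29 log units; within the scatter). The larger move, an 8.6-fold higher number from compound 1 to compound 2 (0.93 log units; beyond the scatter), introduced the aromatic ring itself, and compound 4 keeps that ring, so it offers little guidance here. For the measured compounds named here, no measured compound carries chloro, so this remains an inference from a single small step. In this assay, no change beyond the scatter is therefore expected, and the estimated step is a 1.5-fold lower number from compound 3 to compound 4 (0.18 log units; within the scatter). The expected value for compound 4 is 8500 nM, with an estimated range from 3500 nM to 20000 nM.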

Compound 4, concentration for 50% growth inhibition: 7580 nM
Compound 4: middle estimate off by 1.1-fold (0.05 log units), on the high side; the measured number falls inside the stated range.
By their numbers in this assay, from the lowest: compound 1; then compounds 2, 4 and 3 (each within the scatter of the next).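

With chloro at this aromatic carbon, the same position has now carried three different groups in this assay, and the new numbers stay close: a 1.7-fold lower number from compound 3 to compound 4 (0.23 log units; within the scatter), and a 1.2-fold higher number from compound 2 to compound 4 (0.07 log units; within the scatter), so methyl, nitro and chloro cannot be told apart here. Replacing nitro with chloro takes away two hydrogen-bond acceptors and leaves one heavy atom where there were three, yet this large difference in the counts does not carry the number beyond the scatter. Among the compounds shown here, the clear gap remains the one to the compound without the aromatic ring, a 10-fold higher number from compound 1 to compound 4 (1.00 log units; beyond the scatter), which is of similar size to an 8.6-fold higher number from compound 1 to compound 2 (0.93 log units; beyond the scatter), so in these compounds the larger step goes with adding the ring-bearing group, not with the choice of group on that ring.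

Still open, as far as these compounds go, is whether an amine or a carboxylic acid at this aromatic carbon would stay in the same narrow band, or whether either could bring the number back towards that of compound 1. Nothing else in hand helps explain these numbers.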